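The compounds below may be only part of what the source reports. "The series", "measured", "known", "first", "only" and "open" are said of these compounds alone.

Working notes on the bis-sulfonyl piperidine series.

Compound 1 `CCN(CC)S(=O)(=O)c1ccc(S(=O)(=O)N2CCC[C@@H](C(=O)N[C@@H]3CCN(C(=O)OC(C)(C)C)C3)C2)cc1` is the amide carrying a 1-(tert-butoxycarbonyl)pyrrolidin-3-yl group; in a functional assay on BXPC-3 cells (Homo sapiens) for inhibition, read by MTT assay, with a stated time of 7 days (a lower number here means a stronger inhibitor, a higher number a weaker inhibitor), compound 1 gives 400 nM. Compound 2 `CCOC(=O)[C@@H]1CCCN(S(=O)(=O)c2ccc(S(=O)(=O)N(CC)C(C)C)cc2)C1` is the ethyl ester bearing an ethyl isopropyl sulfonamide; in this assay compound 2 gives 1600 nM. Among the measured compounds shown here, of the two numbers measured so far, compound 1 stands lowest, and its gap to compound 2 lies beyond the usual scatter, so compound 1 is the stronger inhibitor of the pair. For the measured compounds named here, no pair of measured compounds differing in a single place is available, so no measured step size is known for any change in this set.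

Compound 3 `CCN(CC)S(=O)(=O)c1ccc(S(=O)(=O)N2CCC[C@@H](C(=O)NC3CN(C(=O)NC(C)(C)C)C3)C2)cc1` keeps the core and the amide of compound 1 and alters only the group on the amide nitrogen: 1-((tert-butyl)carbamoyl)azetidin-3-yl in place of 1-(tert-butoxycarbonyl)pyrrolidin-3-yl on an amide-type nitrogen. Nothing measured bears directly on this change, so only a modest step is expected, possibly a slight weakening, and it may not exceed the scatter. Compound 3 is expected to give 600 nM in this assay, with a range of 200 nM to 2000 nM. The step this estimate implies, a 1.5-fold higher number from compound 1 to compound 3 (0.18 log units; within the scatter), is expected to be small.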

Compound 3, half-maximal inhibitory concentration: 10100 nM
Beside the measured number, compound 3's estimate is 17-fold (1.23 log units) below it; measured number above the stated range.
By their numbers in this assay, from the lowest: compound 1; then compound 2; then compound 3.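

The group on the amide-type nitrogen is now shown to matter in this assay: 1-((tert-butyl)carbamoyl)azetidin-3-yl in place of 1-(tert-butoxycarbonyl)pyrrolidin-3-yl gives a 25-fold higher number from compound 1 to compound 3 (1.40 log units; beyond the scatter), the first single-place step in the set, and it is large. Several features change together in this one swap, since a four-membered ring replaces a five-membered ring, a hydrogen-bond donor enters, an oxygen gives way to a nitrogen and the defined stereocentre of the leaving group is lost, so this step alone cannot be divided among them. Nothing available explains the weakening.

The compounds shown leave open whether the loss follows the ring or the group on its nitrogen, a question that 1-(tert-butoxycarbonyl)azetidin-3-yl or 1-((tert-butyl)carbamoyl)pyrrolidin-3-yl on the same amide would separate. They also leave open whether the group on the ring nitrogen is needed at all, which a free secondary amine at that place would address.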